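From nitro to bromo: working notes on compound 3

The source may hold more compounds than are shown below. What is called first, only, known or untested is meant among the compounds shown, and "the series" means these compounds.

Compound 1 `Cn1c(-c2ccccc2)cnc1NC(=O)c1ccc(F)cc1` gives > 100000 nM (a limit of the assay)
Compound 2 `Cn1c(-c2ccccc2[N+](=O)[O-])cnc1NC(=O)c1ccc(F)cc1` gives 31000 nM

Among the measured compounds shown here, in a toxicity assay on THP-1 cells (Homo sapiens) for inhibition (a higher number here means that more compound is tolerated, a lower number that less compound is tolerated), compound 2 gives 31000 nM, the only actual number so far. Compound 1 gives > 100000 nM, which is a limit and not a number. For the measured compounds named here, the single measured step, an at least 3.2-fold lower number from compound 1 to compound 2 (0.50 log units; beyond the scatter), lies beyond the scatter and comes with nitro in place of hydrogen on an aromatic carbon.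

Compound 3 `Cn1c(-c2ccccc2Br)cnc1NC(=O)c1ccc(F)cc1` is still unmeasured and carries a change at that same place: bromo in place of nitro on an aromatic carbon. Going by the values given here, no measured step covers bromo, so the only guide is an at least 3.2-fold lower number from compound 1 to compound 2 (0.50 log units; beyond the scatter) for compound 2. A move toward a higher number in this assay is therefore expected, but possibly no larger than the scatter. The expected step is a 1.9-fold higher number from compound 2 to compound 3 (0.29 log units; within the scatter). For compound 3 the estimated value is 60000 nM, with an expected range of 25000 nM to 100000 nM.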

Compound 3, half-maximal cytotoxic concentration: > 100000 nM
Compound 3 was reported as a limit (the forecaster's own chance of this, stated with the estimate: 30%); middle value at least 1.6-fold (0.22 log units) from the limit.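

Bromo in place of nitro at this place, ortho to a large group, gives an at least 3.2-fold higher number from compound 2 to compound 3 (0.50 log units; beyond the scatter) in this assay, so a substituent here does not by itself bring the lower number. Among the compounds shown, the drop belongs to nitro alone: compound 2 is the only one with an actual number, and the hydrogen of compound 1 and the bromo of compound 3 give no such reading. The step between compound 1 and compound 3 cannot be read because both values are limits of the assay: the limit of > 100000 nM in this assay, at which 2 of the 3 values shown sit.

From the compounds shown here alone, how far compound 1 and compound 3 lie from each other therefore stays open. Also open, going by these compounds, is whether an amine or a carboxylic acid at this place would follow nitro or bromo.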